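This account rests on a few compounds, and the source may have more. Where it says the series, first, only, none or still open, it means among the compounds named here.

Compound 3 `CCCc1cc(N)c2cc(NC(=O)/C=C/c3ccc(CC)cc3)ccc2n1` holds the highest of the three numbers measured in a functional assay on HEK293 cells for activation of melanin-concentrating hormone receptor 1 (Homo sapiens), read by inositol phosphate accumulation (a higher number here means that more compound is needed for the effect, a lower number that less compound is needed), where compound 3 gives 160 nM. Compound 1 `CCCc1cc(N)c2cc(NC(=O)/C=C/c3ccc(Cl)cc3)ccc2n1` gives 96 nM and compound 2 `CCCc1cc(N)c2cc(NC(=O)/C=C/c3ccc(SC)cc3)ccc2n1` gives 71 nM. The step of a 1.7-fold higher number from compound 1 to compound 3 (0.22 log units; within the scatter) and the step of a 2.3-fold higher number from compound 2 to compound 3 (0.35 log units; beyond the scatter) both involve the same aromatic carbon, and both were small. Compound 4 `CCCc1cc(N)c2cc(NC(=O)/C=C/c3ccc(C(C)(C)C)cc3)ccc2n1` differs from compound 3 in one place: tert-butyl in place of ethyl on an aromatic carbon. Within the data shown here, no measured step exchanges one alkyl group for a larger one, so the measured steps bear on this change only loosely. One therefore expects in this assay a step for compound 4 of a 1.6-fold higher number from compound 3 to compound 4 (0.21 log units; within the scatter), a modest rise at most. Compound 4 is thus estimated at 260 nM, within a range of 100 nM to 700 nM.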

Compound 4, half-maximal effective concentration: 910 nM
The estimate for compound 4 lay 3.5-fold (0.54 log units) below the measured number; measured number outside the range, above it.
By their numbers in this assay, from the lowest: compounds 2, 1 and 3 (each within the scatter of the next, the first and the last beyond it); then compound 4.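

Exchanges among chloro, methylsulfanyl and ethyl on this aromatic carbon gave modest steps at most in this assay, whereas tert-butyl gives a 5.7-fold higher number from compound 3 to compound 4 (0.75 log units; beyond the scatter). The steps in the same direction, a 9.5-fold higher number from compound 1 to compound 4 (0.98 log units; beyond the scatter) and a 13-fold higher number from compound 2 to compound 4 (1.11 log units; beyond the scatter), set compound 4 apart from all three others, showing that this position does not accept every carbon group alike. No evidence at hand explains this rise.

Going by these compounds, whether branching or carbon count drives the change remains open, and isopropyl or a straight butyl chain would separate the two. On these data alone, how an amine or a methoxy group would behave here also remains open.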